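Notes on the series: compound 4 in the stability read-out

The source may hold more compounds than are shown below. What is called first, only, known or untested is meant among the compounds shown, and "the series" means these compounds.

Three compounds of the shared core have been run in an ADME assay on microsomes from liver (Mus musculus) for metabolic stability; on this read-out higher numbers stand for a longer-lived compound and lower numbers for a shorter-lived compound. Compound 1 `CC(C)NC(=O)CC(c1ccc(-c2ccc3cccc(F)c3c2)[nH]c1=O)C(C)C` gives < 0.0667 h, which is a limit of the assay. Compound 3 `CC(C)C(CC(N)=O)c1ccc(-c2ccc3cccc(F)c3c2)[nH]c1=O` likewise gives < 0.0667 h, again a limit of the assay. Compound 2 `CC(C)C(c1noc(=O)[nH]1)c1ccc(-c2ccc3cccc(F)c3c2)[nH]c1=O` gives > 3 h, a limit at the other end of the assay. Compound 3 therefore stands at the low end of the numbers shown, with the limit of < 0.0667 h in this assay, at which 2 of the 3 values shown sit, and the limit of > 3 h in this assay, at which 1 of the 3 values shown sits, setting the only boundaries the three values offer. The step that the two limits leave unreadable from compound 1 to compound 3 cannot be read. The two steps that touch the upper limit are an at least 44-fold higher number from compound 1 to compound 2 (1.65 log units; beyond the scatter) and an at least 44-fold lower number from compound 2 to compound 3 (1.65 log units; beyond the scatter).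

Compound 4 `CC(C)C(c1ncco1)c1ccc(-c2ccc3cccc(F)c3c2)[nH]c1=O` differs from compound 3 by 1,3-oxazol-2-yl in place of carbamoylmethyl on a saturated chain carbon bound to an aromatic carbon and a saturated chain carbon. Going by the values given here, this is the same kind of change as the one that separates compound 3 from compound 2: a five-membered aromatic ring entering on the saturated chain carbon in place of a group with no ring. Because an at least 44-fold lower number from compound 2 to compound 3 (1.65 log units; beyond the scatter) was large, a large upward step in this assay is expected for compound 4, though not necessarily all the way to the upper limit. Compound 4 is expected to give 0.8 h, between 0.15 h and 3 h. That estimate means an expected step of an at least 11-fold higher number from compound 3 to compound 4 (1.07 log units; beyond the scatter).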

Compound 4, half-life: 0.08 h
Estimate against measurement, compound 4: 10-fold (1.00 log units) above; measured number below the stated range.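

In this assay, a five-membered aromatic ring on the saturated chain carbon does not by itself give a long-lived compound: 1,3-oxazol-2-yl in place of carbamoylmethyl gives an at least 1.1-fold higher number from compound 3 to compound 4 (0.07 log units; that floor lies within the scatter), and in place of (isopropylcarbamoyl)methyl it gives an at least 1.1-fold higher number from compound 1 to compound 4 (0.07 log units; that floor lies within the scatter). The make-up of the ring matters at this position, since replacing the five-membered aromatic ring with 3 hetero atoms of compound 2 by 1,3-oxazol-2-yl gives an at least 37-fold lower number from compound 2 to compound 4 (1.57 log units; beyond the scatter). Of the four compounds, only compound 2 stands at the upper end, and its value is a limit of the assay: the limit of > 3 h in this assay, at which 1 of the 4 values shown sits.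

Which part of the ring of compound 2 separates it from compound 4 stays open, as does whether a tetrazole, a carboxylic acid or a 1,2,4-oxadiazole without the ring carbonyl on the same saturated chain carbon would sit with compound 2 or with compound 4. As far as these compounds go, the true size of the steps to compound 4 from compound 1 and compound 3 also stays open, since both of those compounds are known only through a limit of the assay.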